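Bromo in place of cyano: compound 3 in view

The source may hold more compounds than are shown below. What is called first, only, known or untested is meant among the compounds shown, and "the series" means these compounds.

Going by the values given here, in a functional assay on MCF7 cells (Homo sapiens) for inhibition, read by MTT assay, with a stated time of 72 h, tested at 30 uM (on this read-out lower numbers stand for less inhibition of growth and higher numbers for more inhibition of growth at the one concentration tested), compound 1 `C=CCc1ccc(OCc2cn(-c3ccc(C#N)cc3)nn2)c(O)c1` gives 35.7%, the lower of the two numbers so far, and compound 2 `C=CCc1cc(O)c(O)c(CN2CCC(Cc3ccccc3)CC2)c1` gives 70.9%, a gap beyond the scatter. Compound 3 `C=CCc1ccc(OCc2cn(-c3ccc(Br)cc3)nn2)c(O)c1` carries bromo in place of cyano on an aromatic carbon, para to a large group: bromo in place of cyano on an aromatic carbon. Among the compounds with values here, no measured step covers this change, so the expectation rests on the structural change alone: a small rise in this assay, not clearly beyond the scatter. The estimated step is a number 6.3 percentage points higher from compound 1 to compound 3 (within the scatter). The estimate for compound 3 is 42%, with an expected range of 22% to 62%.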

Compound 3, percent growth inhibition at one concentration: 19.4%
Estimate against measurement, compound 3: 22.6 percentage points above, and the stated range ends above it.
By their numbers in this assay, from the lowest: compound 3; then compound 1; then compound 2.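

Working notes: in this assay, the change from 4-cyanophenyl to 4-bromophenyl gives a number 16.3 percentage points lower from compound 1 to compound 3 (beyond the scatter) and is the only measured step in the series so far. It shows that growth inhibition at this position depends on the group carried on the aromatic carbon, with cyano ahead of bromo in this single pair. No measurement here bears on the reason for this step.

As far as these compounds go, it remains open how an amine or a carboxylic acid at this position would read against cyano and bromo. A single pair also leaves open whether the step holds on any other core.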